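This account rests on a few compounds, and the source may have more. Where it says the series, first, only, none or still open, it means among the compounds named here.

For the measured compounds named here, compound 1 `Cc1nc(NCc2ccco2)c2cnn(-c3ccccc3)c2n1` is the only member of this small set with a numerical result: in a functional assay on G-361 cells (Homo sapiens) for cytotoxicity, read by sulforhodamine B assay (on this read-out lower numbers stand for stronger inhibition of growth and higher numbers for weaker inhibition of growth), compound 1 gives 39000 nM. Compound 2 `Cc1nc(Nc2ccccc2)c2cnn(-c3ccccc3)c2n1` reaches only the limit of the measurement, giving > 100000 nM in this assay. Compound 3 `Cc1nc(NCc2ccccc2)c2cnn(-c3ccccc3)c2n1` likewise sits at a limit, with > 100000 nM. Both changes away from compound 1 weaken growth inhibition: an at least 2.5-fold higher number from compound 1 to compound 2 (0.40 log units; beyond the scatter) and an at least 2.5-fold higher number from compound 1 to compound 3 (0.40 log units; beyond the scatter), while a step that the two limits leave unreadable from compound 2 to compound 3 because of the limit of > 100000 nM in this assay, at which 2 of the 3 values shown sit. Going by the values given here, compound 4 `c1ccc(NCc2nc(Nc3ccccc3)c3cnn(-c4ccccc4)c3n2)cc1` differs from compound 2 by anilino in place of hydrogen on a saturated chain carbon bound to an aromatic carbon, a position untouched in any measured pair, so no measured step speaks directly to it. The step this estimate means, a number no higher from compound 2 to compound 4 (the limit leaves the size open), is expected to remain unreadable against a limit. Compound 4 is expected near 100000 nM, within 30000 nM to 300000 nM, most likely reported again as a limit.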

Compound 4, concentration for 50% growth inhibition: > 100000 nM
Compound 4: a limit, no number; the forecaster's own chance of this, stated with the estimate: 70%; the middle value sits exactly at the limit.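

No size can be read for the change from compound 2 to compound 4, because both stop at a limit: the limit of > 100000 nM in this assay, at which 3 of the 4 values shown sit. The compounds shown leave open whether anilino on that saturated chain carbon changes growth inhibition at all.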